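Trifluoromethyl for Methyl on a Benzyl-Bearing Sulfonamide

This account rests on a few compounds, and the source may have more. Where it says the series, first, only, none or still open, it means among the compounds named here.

Compound 3 `CCOC(=O)c1oc2ccc(N(Cc3ccccc3)S(=O)(=O)c3ccc(C)cc3)cc2c1C` carries a 4-methylphenyl group on the sulfonyl sulfur and a benzyl group on the sulfonamide nitrogen. In a functional assay on HCT-116 cells (Homo sapiens) for inhibition, read by MTT assay, with a stated time of 72 h (on this read-out higher numbers stand for weaker inhibition and lower numbers for stronger inhibition), compound 3 reaches only the limit of the assay, > 40000 nM. Compound 2 `CCOC(=O)c1oc2ccc(N(Cc3ccccc3)S(=O)(=O)c3ccccc3Br)cc2c1C`, which bears 2-bromophenyl on the sulfonyl sulfur instead, likewise stands at a limit in this assay, > 40000 nM. The step that the two limits leave unreadable from compound 2 to compound 3 therefore cannot be read. Compound 1 `CCOC(=O)c1oc2ccc(NS(=O)(=O)c3ccc(C(F)(F)F)cc3)cc2c1C`, which keeps the amide hydrogen and carries 4-(trifluoromethyl)phenyl, gives 5030 nM in this assay. Compound 4 `CCOC(=O)c1oc2ccc(N(Cc3ccccc3)S(=O)(=O)c3ccc(C(F)(F)F)cc3)cc2c1C` differs from compound 3 by trifluoromethyl in place of methyl on an aromatic carbon. For the measured compounds named here, no measured step bears directly on this exchange; what the numbers show is the limit of > 40000 nM in this assay, at which 2 of the 3 values shown sit, where both benzyl-bearing compounds, compound 2 and compound 3, sit, while compound 1, the only compound with a measured number, lacks that benzyl group. Compound 4 keeps the benzyl group, so it is expected to remain at or near the limit, and the expected step of a number no higher from compound 3 to compound 4 (the limit leaves the size open) is not readable in size. Compound 4 is therefore estimated at 40000 nM, within 15000 nM to 90000 nM.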

Compound 4, half-maximal inhibitory concentration: 26700 nM
Estimate against measurement, compound 4: 1.5-fold (0.18 log units) above; low and high end bracket the measured number.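

In this assay, compound 4 is the only benzyl-bearing compound shown with a number, so the benzyl group in place of hydrogen on the sulfonamide nitrogen can now be sized, at a 5.3-fold higher number from compound 1 to compound 4 (0.72 log units; beyond the scatter). At the group on the sulfonyl sulfur, the comparisons give only floors, an at least 1.4-fold lower number from compound 3 to compound 4 (0.17 log units; that floor lies within the scatter) and an at least 1.4-fold lower number from compound 2 to compound 4 (0.17 log units; that floor lies within the scatter), so neither the exchange of methyl for trifluoromethyl nor that of 2-bromophenyl for 4-(trifluoromethyl)phenyl is shown to change the read-out beyond the scatter, although the true size of either step could be larger. Compound 2 and compound 3 remain limits of the assay and not numbers: the limit of > 40000 nM in this assay, at which 2 of the 4 values shown sit.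

From the compounds shown here alone, whether a shorter or longer chain in place of benzyl on the sulfonamide nitrogen would give a number nearer that of compound 1 or that of compound 4 remains open, as does the effect of an amine on the benzyl ring. Also open, going by these compounds, is whether a carboxylic acid in place of the ethyl ester on the shared core would move the number in either direction.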